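Aryl group swap on the shared core: estimate for compound 4

The source may report more compounds than this note shows. Statements on the series, on what has been measured and on what is new or still open speak of the compounds shown alone.

Three analogues of the shared core have numbers in a functional assay on A549 cells (Homo sapiens) for inhibition, read by MTT assay, with a stated time of 72 h; on this read-out lower numbers stand for stronger inhibition and higher numbers for weaker inhibition. Compound 1 `COc1cc2c(Oc3ccc(NC(=O)c4nn(-c5ccccc5)c(=O)cc4C)cc3F)ccnc2cc1OCCCN1CCCC1` carries an unsubstituted phenyl, and in this assay compound 1 gives 370 nM. Compound 2 `COc1cc2c(Oc3ccc(NC(=O)c4nn(-c5ccccc5C(F)(F)F)c(=O)cc4C)cc3F)ccnc2cc1OCCCN1CCCC1` carries a 2-(trifluoromethyl)phenyl; in this assay compound 2 gives 130 nM. Compound 3 `COc1cc2c(Oc3ccc(NC(=O)c4nn(-c5cccc(F)c5)c(=O)cc4C)cc3F)ccnc2cc1OCCCN1CCCC1` carries a 3-fluorophenyl, and in this assay compound 3 gives 170 nM, the second highest of the three numbers: it sits within the scatter of compound 2 and apart from compound 1.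

The next compound, compound 4 `COc1cc2c(Oc3ccc(NC(=O)c4nn(-c5ccc(Cl)cc5)c(=O)cc4C)cc3F)ccnc2cc1OCCCN1CCCC1`, differs from compound 3 in one place: 4-chlorophenyl in place of 3-fluorophenyl on an aromatic nitrogen. Among the measured compounds shown here, no measured step involves a chloro group or a 4-chlorophenyl. For the measured compounds named here, the steps that bear on the change are those that put a substituent onto the phenyl on the aromatic nitrogen: a 2.8-fold lower number from compound 1 to compound 2 (0.45 log units; beyond the scatter) and a 2.2-fold lower number from compound 1 to compound 3 (0.34 log units; beyond the scatter), both modest and in the same direction, while a 1.3-fold higher number from compound 2 to compound 3 (0.12 log units; within the scatter) shows that the two substituted phenyls measured so far lie within the scatter of each other. Compound 4 keeps a substituted phenyl, so the expected step is a 1.1-fold lower number from compound 3 to compound 4 (0.05 log units; within the scatter), most likely within the scatter and without a clear direction. Compound 4 is estimated at 150 nM, with a range of 60 nM to 400 nM.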

Compound 4, half-maximal inhibitory concentration: 230 nM
Compound 4: middle estimate off by 1.5-fold (0.19 log units), on the low side; the measured number falls inside the stated range.
By their numbers in this assay, from the lowest: compounds 2, 3, 4 and 1 (each within the scatter of the next, the first and the last beyond it).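

In this assay, the 4-chlorophenyl keeps compound 4 close to both earlier substituted phenyls, with a 1.4-fold higher number from compound 3 to compound 4 (0.13 log units; within the scatter) and a 1.8-fold higher number from compound 2 to compound 4 (0.25 log units; within the scatter), each step within the scatter. The new point is a 1.6-fold lower number from compound 1 to compound 4 (0.21 log units; within the scatter), also within the scatter: unlike a 2.8-fold lower number from compound 1 to compound 2 (0.45 log units; beyond the scatter) and a 2.2-fold lower number from compound 1 to compound 3 (0.34 log units; beyond the scatter), this substituent on the phenyl does not separate clearly from the unsubstituted phenyl, so compound 4 goes against any reading that every substituent here gives a step beyond the scatter. Nothing available explains this difference between the chloro step and the two earlier steps.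

The step to compound 4 changes both the halogen and its place on the phenyl, so the compounds shown cannot separate these two changes. They also leave open how this position responds to a group other than a halogen or trifluoromethyl, such as a methoxy group, an amine or a carboxylic acid on the phenyl.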